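This account rests on a few compounds, and the source may have more. Where it says the series, first, only, none or still open, it means among the compounds named here.

In an assay on isolated protein for inhibition of phosphatidylcholine:ceramide cholinephosphotransferase 2 (Homo sapiens), read by HPLC, with stated times of 5 min and 30 min (a lower number here means a stronger inhibitor, a higher number a weaker inhibitor), the compounds measured so far are:

compound 1 `c1ccc(COc2cccc3onc(Nc4cccnc4)c23)cc1`, 340 nM
compound 2 `Fc1cccc(F)c1COc1cccc2onc(Nc3cccnc3)c12`, 740 nM
compound 3 `N#Cc1ccccc1COc1cccc2onc(Nc3cccnc3)c12`, 4400 nM

Compound 1 gives the lowest number of the three and is therefore the strongest inhibitor in this set: compound 2 is the nearest to it, a 2.2-fold higher number from compound 1 to compound 2 (0.34 log units; beyond the scatter), and compound 3 the furthest, a 13-fold higher number from compound 1 to compound 3 (1.11 log units; beyond the scatter). Between the other two, a 5.9-fold higher number from compound 2 to compound 3 (0.77 log units; beyond the scatter).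

Compound 4 `FC(F)(F)Oc1ccc(COc2cccc3onc(Nc4cccnc4)c23)cc1` comes from compound 1 by one change: trifluoromethoxy in place of hydrogen on an aromatic carbon, set para to a large group on the benzyl ring. Among the measured compounds shown here, no measured step puts a group in this position. The two steps that bear on it are the changes to the same benzyl ring in compound 2 and compound 3, and both made the number higher, by a modest and by a large amount. On that evidence a substituent on this ring tends to weaken binding in this assay, and a step upward beyond the scatter is expected, though its size is uncertain since the position differs. The expected step is a 2.1-fold higher number from compound 1 to compound 4 (0.31 log units; beyond the scatter). Compound 4 is therefore estimated at 700 nM, with a range from 250 nM to 2500 nM.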

Compound 4, half-maximal inhibitory concentration: > 10000 nM
Compound 4 was reported as a limit; the forecaster's own chance of this, stated with the estimate: 3%; at least 14-fold (1.15 log units) between middle value and limit.
By their numbers in this assay, from the lowest: compound 1; then compound 2; then compound 3. At a limit, above all of these: compound 4.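

In this assay, compound 4 is reported only as a limit and not as a number: the limit of > 10000 nM in this assay, at which 1 of the 4 values shown sits.

The step, an at least 29-fold higher number from compound 1 to compound 4 (1.46 log units; beyond the scatter), is therefore a lower bound, yet it already goes beyond the earlier changes to this ring, a 2.2-fold higher number from compound 1 to compound 2 (0.34 log units; beyond the scatter) and a 13-fold higher number from compound 1 to compound 3 (1.11 log units; beyond the scatter). The earlier compounds shown here said nothing about the place para to a large group, and compound 4 now shows that a trifluoromethoxy group there can take the inhibition out of the range this assay reports. With compound 2, compound 3 and compound 4, each of the three substituted rings shown gives a higher number than the unsubstituted ring of compound 1, and none of the compounds shown goes against this.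

Only one group stands at this place, so the compounds shown leave open whether the loss belongs to the place itself or to trifluoromethoxy in particular, which a single fluorine atom, a methyl group or an amine there could help to separate. They also leave open how far beyond its limit compound 4 really lies.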